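The source may report more compounds than this note shows. Statements on the series, on what has been measured and on what is new or still open speak of the compounds shown alone.

Working notes on the series. Compound 3 `COc1ccc(C(=O)/C=C/c2cc(-c3cc(OC)c(OC)c(OC)c3)n[nH]2)cc1` gives 90% in a functional assay on RXF 393 cells (Homo sapiens) for cytotoxicity, read by sulforhodamine B assay, with a stated time of 48 h, tested at 0.1 uM; a lower number here means a stronger effect, a higher number a weaker effect of the compound at the concentration tested. Compound 1 `COc1cc(-c2cc(/C=C/C(=O)c3ccc(N)cc3)[nH]n2)cc(OC)c1OC` gives 91% in this assay, and compound 2 `COc1cc(-c2cc(/C=C/C(=O)c3ccc(Cl)c(Cl)c3)[nH]n2)cc(OC)c1OC` gives 96%. Compound 3 holds the lowest of the three numbers, yet the step of a number 1 percentage points lower from compound 1 to compound 3 (within the scatter) and the step of a number 6 percentage points lower from compound 2 to compound 3 (within the scatter) both fall within the scatter, so the three compounds cannot be told apart on these numbers.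

Compound 4 `COc1cc(-c2cc(/C=C/C(=O)c3ccc(F)c(F)c3)[nH]n2)cc(OC)c1OC` is not yet measured in this assay. It differs from compound 3 in one place: 3,4-difluorophenyl in place of 4-methoxyphenyl on a carbonyl carbon. The measured steps that bear on this change are those at the same place, the carbonyl carbon: a number 5 percentage points higher from compound 1 to compound 2 (within the scatter) and a number 6 percentage points lower from compound 2 to compound 3 (within the scatter), both within the scatter. Exchanging the aryl group on the carbonyl carbon has so far moved the number only by amounts within the scatter. For the measured compounds named here, no measured compound carries a 3,4-difluorophenyl group, so no direct step exists for it. The expected step of a number 3 percentage points higher from compound 3 to compound 4 (within the scatter) is therefore one of no size beyond the scatter, in no particular direction. Compound 4 is estimated at 93%, with a range from 84% to 100%.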

Compound 4, a percentage reported as activity, at one concentration (the size of the read-out at that concentration, not a potency): 96%
The estimate for compound 4 lay 3 percentage points below the measured number; low and high end bracket the measured number.
By their numbers in this assay, from the lowest: compounds 3, 1, 2 and 4 (each within the scatter of the next).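

The 3,4-difluorophenyl group on the carbonyl carbon is a fourth aryl group at this place, and it gives a number 6 percentage points higher from compound 3 to compound 4 (within the scatter) and a number 5 percentage points higher from compound 1 to compound 4 (within the scatter) in this assay without separating compound 4 from either. Exchanging chlorine for fluorine on the same ring pattern gives no change at the digits printed from compound 2 to compound 4 (within the scatter) and so adds a pair of halogen-bearing compounds that cannot be told apart. Nothing available explains these numbers or their closeness.

On these data alone, all four compounds share the core and differ only in the aryl group on the carbonyl carbon, so whether any group at this place can move the number beyond the scatter stays open. A saturated amine such as piperidine in place of the aryl group, or a carboxylic acid on the ring, would put that question to a more different structure.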